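The source may report more compounds than this note shows. Statements on the series, on what has been measured and on what is new or still open speak of the compounds shown alone.

In a functional assay, read by spectrophotometry, with a stated time of 30 min (on this read-out higher numbers stand for weaker inhibition and lower numbers for stronger inhibition), compound 1 `O=C(/C=C/c1ccccc1)NCCC1CCN(Cc2ccccc2)CC1` gives > 200000 nM, which is a limit of the assay and not a number. Going by the values given here, compound 2 `Cc1ccccc1CN1CCC(CCNC(=O)/C=C/c2cc(C(C)(C)C)c(O)c(C(C)(C)C)c2)CC1` gives 65300 nM, the only true number so far. Compound 3 `CC(C)(C)c1cc(/C=C/C(=O)NCCC2CCN(Cc3ccc(F)cc3F)CC2)cc(C(C)(C)C)c1O` differs from compound 2 in one place: 2,4-difluorophenyl in place of 2-methylphenyl on a saturated chain carbon bound to an amine nitrogen in a ring. It carries 2,4-difluorophenyl in place of 2-methylphenyl on a saturated chain carbon bound to an amine nitrogen in a ring. Among the compounds with values here, no measured pair shows what such a change does here, so no shift beyond the usual scatter is expected in either direction. The estimated step is a 1.3-fold lower number from compound 2 to compound 3 (0.12 log units; within the scatter). Compound 3 is expected at about 50000 nM, with an estimated range of 15000 nM to 150000 nM.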

Compound 3, half-maximal inhibitory concentration: 62400 nM
Compound 3: the middle estimate sits 1.2-fold (0.10 log units) below what was measured; the measured number falls inside the stated range.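

On a saturated chain carbon bound to an amine nitrogen in a ring, 2,4-difluorophenyl can replace 2-methylphenyl with no clear effect, the step being a 1.0-fold lower number from compound 2 to compound 3 (0.02 log units; within the scatter). This position therefore accepts two differently substituted phenyl rings equally well, which compound 2 alone could not show. Nothing measured here explains why the two groups read alike. Still open, from the compounds shown here alone, is whether the position accepts something other than a substituted phenyl ring, such as a pyridine ring or a cyclohexyl group. Going by these compounds, a longer chain between that ring and the amine nitrogen also remains untested in these compounds.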